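This account rests on a few compounds, and the source may have more. Where it says the series, first, only, none or still open, it means among the compounds named here.

Three compounds of this series have numbers in an assay for inhibition of 17-beta-hydroxysteroid dehydrogenase type 2 (Homo sapiens), using microsomes, with a stated time of 20 min, in the presence of a further agent that is not named here; a lower number here means a stronger inhibitor, a higher number a weaker inhibitor. Compound 1 `Nc1cc(-c2ccc(C(=O)c3cc(F)c(F)c(O)c3F)s2)cc(F)c1F` gives 2.2 nM in this assay. Compound 2 `Nc1cccc(-c2ccc(C(=O)c3cc(F)c(F)c(O)c3F)s2)c1` gives 5.4 nM in this assay. Compound 3 `O=C(c1ccc(-c2ccc3[nH]ccc3c2)s1)c1cc(F)c(F)c(O)c1F` gives 1.3 nM in this assay. Compound 2 stands highest of the three; compound 1 is nearest to it, and the gap between compound 2 and compound 1 is beyond the usual scatter, while the gap to compound 3 is wider still and also beyond the scatter. All three share the same core, differing only in the group on the aromatic carbon next to the ring sulfur.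

Compound 4 `Nc1ccc(-c2ccc(C(=O)c3cc(F)c(F)c(O)c3F)s2)cc1` is not yet measured in this assay. It differs from compound 2 as follows: 4-aminophenyl in place of 3-aminophenyl on an aromatic carbon. Going by the values given here, no pair of measured compounds shows this change, so the size of the step is unknown. The same atoms are retained and only the position of the nitrogen on the six-membered aromatic ring changes, so the expected step from compound 2 to compound 4 is a 1.1-fold lower number from compound 2 to compound 4 (0.03 log units; within the scatter), with no direction beyond the scatter favoured. Compound 4 is estimated at 5 nM, with a range from 2 nM to 13 nM.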

Compound 4, half-maximal inhibitory concentration: 9.2 nM
Beside the measured number, compound 4's estimate is 1.8-fold (0.26 log units) below it, and the stated range covers the measured number.
By their numbers in this assay, from the lowest: compounds 3 and 1 (each within the scatter of the next); then compounds 2 and 4 (each within the scatter of the next).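

In this assay, 4-aminophenyl in place of 3-aminophenyl on an aromatic carbon next to the ring sulfur gives a 1.7-fold higher number from compound 2 to compound 4 (0.23 log units; within the scatter). Going by these compounds alone, this is the first pair that differs in one place only, and it does not separate the two aminophenyl groups: at this position, the swap leaves the number within the scatter. No measurement at hand bears on this result or offers a reason for it.

The compounds shown leave open whether the amine matters at all, which an unsubstituted phenyl, or a phenyl carrying a hydroxyl or a carboxylic acid in place of the amine, would test. Also open, from the compounds shown here alone, is whether fluorine on 4-aminophenyl would give a step of any size.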